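The source may hold more compounds than are shown below. What is called first, only, known or untested is meant among the compounds shown, and "the series" means these compounds.

Measured so far in a functional assay on the whole organism (strain Sprague-Dawley) for inhibition, with Rattus norvegicus as the target; on this read-out higher numbers stand for an effect only at larger amounts of compound and lower numbers for an effect already at smaller amounts:
- compound 1 `Cc1cc([N+](=O)[O-])c2cc(-c3nn[nH]n3)cnc2c1C`: 2.5 mg/kg
- compound 2 `Cc1cccc2cc(C(=O)O)cnc12`: a limit of the assay, > 50 mg/kg
- compound 3 `Cc1ccc2cc(C(=O)O)cnc2c1C`: 25 mg/kg

Compound 3 carries the highest number among the two numbers shown; the nearest is compound 1, whose number is lower by an at least 2.0-fold lower number from compound 2 to compound 3 (0.30 log units; that floor lies within the scatter) in scale terms is the only measured step, and it goes the other way in structure: an at least 2.0-fold lower number from compound 2 to compound 3 (0.30 log units; that floor lies within the scatter), methyl in place of hydrogen on an aromatic carbon. Compound 2 sits at the limit noted under (the limit of > 50 mg/kg in this assay, at which 1 of the 3 values shown sits).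

Compound 4 `Cc1ccc2cc(-c3nn[nH]n3)cnc2c1C` differs from compound 3 by 2H-tetrazol-5-yl in place of carboxy on an aromatic carbon. Going by the values given here, no measured step covers this change on its own: compound 1 carries the same 2H-tetrazol-5-yl group but also a nitro group, so the gap between compound 1 and compound 3 mixes two changes and cannot be split. The step from the measured pair concerns a methyl and bears only loosely here. Taking compound 1 as the nearest guide, a lower number is expected for compound 4, by a 2.5-fold lower number from compound 3 to compound 4 (0.40 log units; beyond the scatter), with wide uncertainty. Compound 4 is estimated at 10 mg/kg, within 3 mg/kg to 30 mg/kg.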

Compound 4, minimum effective dose: 1 mg/kg
Compound 4: middle estimate off by 10-fold (1.00 log units), on the high side; measured number outside the range, below it.
By their numbers in this assay, from the lowest: compound 4; then compound 1; then compound 3. At a limit, above all of these: compound 2.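

In this assay, the exchange of carboxy for 2H-tetrazol-5-yl on this aromatic carbon, two atoms from the ring nitrogen, can now be read on its own, and it gives a 25-fold lower number from compound 3 to compound 4 (1.40 log units; beyond the scatter). The nitro group, previously mixed with that exchange in the gap between compound 1 and compound 3, also separates out: hydrogen in place of nitro gives a 2.5-fold lower number from compound 1 to compound 4 (0.40 log units; beyond the scatter), so the nitro group is not needed for the low dose seen with 2H-tetrazol-5-yl. Nothing measured here gives a reason for either step.

Going by these compounds, whether the same exchange holds on the core of compound 2, which lacks the extra methyl, remains open. Also open, on these data alone, is how other groups would compare, such as a sulfonic acid or an amide in place of 2H-tetrazol-5-yl, or an amine in place of nitro.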